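The compounds below may be only part of what the source reports. "The series", "measured", "known", "first", "only" and "open" are said of these compounds alone.

Compound 1 `O=C(Nc1cc(-c2ccccc2)nn1-c1ccccc1)c1ccccc1` gives 300 nM in an assay on isolated protein with metabotropic glutamate receptor 5 (Rattus norvegicus) as the target (on this read-out higher numbers stand for an effect only at larger amounts of compound and lower numbers for an effect already at smaller amounts), the second highest of the three numbers. Compound 2 `O=C(Nc1cc(-c2ccccc2)nn1-c1ccccc1)c1ccccn1` gives 585 nM, and a 2.0-fold higher number from compound 1 to compound 2 (0.29 log units; within the scatter). Compound 3 `O=C(Nc1cc(-c2ccccc2)nn1-c1ccccc1)c1ccccc1F` gives 100 nM, and a 3.0-fold lower number from compound 1 to compound 3 (0.48 log units; beyond the scatter); between the other two, a 5.9-fold lower number from compound 2 to compound 3 (0.77 log units; beyond the scatter). Compound 4 `O=C(Nc1cc(-c2ccccc2)nn1-c1ccccc1)c1cccc(F)c1` differs from compound 1 by fluoro in place of hydrogen on an aromatic carbon. The measured step most like this one is that from compound 1 to compound 3, also a fluoro in place of hydrogen on an aromatic carbon, which gave a modest lowering; the step from compound 2 to compound 3 points the same way. A modest lowering is therefore expected in this assay, with the estimate for compound 4 being a 1.8-fold lower number from compound 1 to compound 4 (0.25 log units; within the scatter), that is 170 nM with a range from 70 nM to 450 nM.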

Compound 4, half-maximal effective concentration: 65 nM
Compound 4: the middle estimate sits 2.6-fold (0.42 log units) above what was measured, outside the stated range (below it).
By their numbers in this assay, from the lowest: compounds 4 and 3 (each within the scatter of the next); then compounds 1 and 2 (each within the scatter of the next).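

In this assay the step of a 4.6-fold lower number from compound 1 to compound 4 (0.66 log units; beyond the scatter) shows that fluoro lowers the number as 3-fluorophenyl too, not only as the 2-fluorophenyl of compound 3. The two fluoro placements cannot be told apart, with a 1.5-fold lower number from compound 3 to compound 4 (0.19 log units; within the scatter) separating them, and a 9.0-fold lower number from compound 2 to compound 4 (0.95 log units; beyond the scatter) is the widest gap among the compounds shown. Nothing measured here offers a reason for these numbers.

As far as these compounds go, whether a methoxy or an amine on the same aromatic carbon would behave like fluoro stays open. So does whether a second fluoro would add to the first.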